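Nitro on the fluorophenyl ring of compound 3

The source may hold more compounds than are shown below. What is called first, only, known or untested is meant among the compounds shown, and "the series" means these compounds.

Three compounds of the series have a number in an assay for inhibition of Thromboxane-A synthase (Homo sapiens), using microsomes; a higher number here means a weaker inhibitor, a lower number a stronger inhibitor. Compound 1 `O=C(O)CC/C=C\CC1COC(c2ccccc2Cl)OC1c1cccnc1` gives 48 nM; compound 2 `O=C(O)CC/C=C\CC1COC(c2cccnc2)OC1c1cccnc1` gives 220 nM; compound 3 `CC(C)(Oc1ccc(F)cc1)C1OCC(C/C=C\CCC(=O)O)C(c2cccnc2)O1` gives 51 nM. Compound 3 thus sits with compound 1, the two values within the scatter of each other, and clearly lower than compound 2. Among the measured compounds shown here, the one measured step, a 4.6-fold higher number from compound 1 to compound 2 (0.66 log units; beyond the scatter), concerns the substituent on a saturated ring carbon of the shared core and is modest.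

Compound 4 `CC(C)(Oc1ccc(F)cc1[N+](=O)[O-])C1OCC(C/C=C\CCC(=O)O)C(c2cccnc2)O1` differs from compound 3 in one place: nitro in place of hydrogen on an aromatic carbon. For the measured compounds named here, no measured step touches the 4-fluorophenyl group; the step from compound 1 to compound 2 is a different kind of change on another part of the core and gives no direct guide. With nothing to draw on but the size of that single step, the expectation is that the change in this assay stays close to compound 3, no step beyond the scatter in either direction, worded as a 1.1-fold higher number from compound 3 to compound 4 (0.03 log units; within the scatter). Compound 4 is therefore expected to give about 55 nM in this assay, within a range from 20 nM to 160 nM.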

Compound 4, half-maximal inhibitory concentration: 20 nM
Compound 4: middle estimate off by 2.8-fold (0.44 log units), on the high side; measured number inside the range.
By their numbers in this assay, from the lowest: compound 4; then compounds 1 and 3 (each within the scatter of the next); then compound 2.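

In this assay, among the compounds shown here, the 4-fluorophenyl group of compound 3 proves open to change: moving to 4-fluoro-2-nitrophenyl gives a 2.6-fold lower number from compound 3 to compound 4 (0.41 log units; beyond the scatter), a modest step but one beyond the scatter, and the first measured step at this part of the series. The aromatic carbon ortho to a large group and meta to the fluoro group therefore accepts nitro, with its 3 heavy atoms in place of a hydrogen atom, and the number goes down rather than up, which the step from a 2-chlorophenyl to a pyridin-3-yl group elsewhere on the shared core could not show. No measurement at hand bears on what lies behind this step.

As far as these compounds go, it remains open whether the lower number is specific to nitro or would also appear with another group on this carbon, such as an amine, a nitrile or a methoxy group. Also open, from the compounds shown here alone, is whether nitro on a different carbon of this ring, or nitro with the fluoro group replaced by hydrogen, would give a step of similar size.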